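The source may report more compounds than this note shows. Statements on the series, on what has been measured and on what is new or still open speak of the compounds shown alone.

Measured so far:
compound 1, `O=C1COc2ccc(-c3ccc(O)cc3)cc2N1` — > 40000 nM
compound 2, `COc1ncc(-c2ccc3c(c2)N(c2ccc(F)cc2)C(=O)CO3)cc1NS(=O)(=O)c1ccc(F)cc1` — 10500 nM
compound 3, `O=C1COc2ccc(-c3cnc4ccccc4c3)cc2N1c1ccc(Cl)cc1` — > 40000 nM

Compound 1 carries an unsubstituted amide nitrogen on the shared core. In a functional assay on HeLa cells (Homo sapiens) for antiproliferative activity, read by MTT assay, with a stated time of 72 h (on this read-out lower numbers stand for stronger inhibition and higher numbers for weaker inhibition), compound 1 gives only > 40000 nM, which is a limit of the assay rather than a number. Going by the values given here, compound 2 is the one member of the set with a numerical value, giving 10500 nM in this assay. Compound 3 gives > 40000 nM in this assay, again a limit. Among the compounds with values here, compound 1 therefore sits at the limit of > 40000 nM in this assay, at which 2 of the 3 values shown sit, and no measured step to or from it can be sized.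

Compound 4, `COc1cccc(N2C(=O)COc3ccc(-c4ccc(O)cc4)cc32)c1`, differs from compound 1 by 3-methoxyphenyl in place of hydrogen on an amide-type nitrogen in a ring. Compounds 2 and 3 both carry an aryl group on the same nitrogen, one with a number and one at the limit, so the pairing gives no settled direction. The step of an at least 1.6-fold lower number from compound 1 to compound 4 (0.20 log units; that floor lies within the scatter) is expected to be small or to stay within the scatter. Compound 4 is estimated at 25000 nM, with a range from 6000 nM to 40000 nM.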

Compound 4, half-maximal inhibitory concentration: > 40000 nM
Compound 4 was reported as a limit; the forecaster's own chance of this, stated with the estimate: 50%; middle value at least 1.6-fold (0.20 log units) from the limit.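

In this assay compound 4 gives > 40000 nM as a limit of the assay, not a number. Going by these compounds alone, compound 1 also stands at a limit, so no step between compound 1 and compound 4 can be read: the limit of > 40000 nM in this assay, at which 3 of the 4 values shown sit. The compounds shown leave open whether 3-methoxyphenyl in place of hydrogen on the amide-type nitrogen changes antiproliferative activity at all, and in which direction.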